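Methoxycarbonyl for 1-methylethenyl on the fused ring

This account rests on a few compounds, and the source may have more. Where it says the series, first, only, none or still open, it means among the compounds named here.

Compound 3 `C=C(C)c1ccc2c(c1)c(=O)c(C(=O)Nc1ccc(Oc3ncnc4[nH]cc(-c5ccccc5)c34)c(F)c1)c(C)n2C` gives 170 nM in an assay on isolated protein for inhibition of tyrosine-protein kinase receptor UFO (Homo sapiens), read by FRET and Z'-LYTE, with a stated time of 1.5 h (on this read-out higher numbers stand for weaker inhibition and lower numbers for stronger inhibition), the lowest of the two numbers shown. Compound 2 `CCc1ccc2c(c1)c(=O)c(C(=O)Nc1ccc(Oc3ncnc4[nH]cc(-c5ccccc5)c34)c(C)c1)c(C)n2C` gives 1120 nM in this assay, a higher number beyond the scatter. Compound 1 `Cc1c(C(=O)Nc2ccc(Oc3ncnc4[nH]cc(-c5ccccc5)c34)c(F)c2)c(=O)c2ccccc2n1C` reaches only a limit in this assay, > 10000 nM (the limit of > 10000 nM in this assay, at which 1 of the 3 values shown sits). Within the data shown here, the one measured step at this position is an at least 58-fold lower number from compound 1 to compound 3 (1.76 log units; beyond the scatter), a large gain from adding the 1-methylethenyl group.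

Compound 4 `COC(=O)c1ccc2c(c1)c(=O)c(C(=O)Nc1ccc(Oc3ncnc4[nH]cc(-c5ccccc5)c34)c(F)c1)c(C)n2C` carries methoxycarbonyl in place of 1-methylethenyl on an aromatic carbon. Among the measured compounds shown here, no measured step covers methoxycarbonyl, so only the sensitivity of this position to substitution, seen in an at least 58-fold lower number from compound 1 to compound 3 (1.76 log units; beyond the scatter), guides the guess. On that basis the expected change is a 2.6-fold higher number from compound 3 to compound 4 (0.42 log units; beyond the scatter), a moderate loss with wide uncertainty. For compound 4 the estimate in this assay is 450 nM, between 100 nM and 2500 nM.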

Compound 4, half-maximal inhibitory concentration: > 10000 nM
Compound 4 gave a limit, no number; the forecaster's own chance of this, stated with the estimate: 5%; middle value at least 22-fold (1.34 log units) from the limit.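

In this assay methoxycarbonyl in place of 1-methylethenyl gives an at least 58-fold higher number from compound 3 to compound 4 (1.76 log units; beyond the scatter) on this aromatic carbon. The earlier gain from 1-methylethenyl therefore does not extend to every group placed here, and the identity of the group matters, not just the presence of one. Compound 4 stands at a limit, not a number, as does compound 1, so the step between them cannot be read: the limit of > 10000 nM in this assay, at which 2 of the 4 values shown sit.

Still open, as far as these compounds go, is whether an amine, a carboxylic acid or a longer alkyl chain at this carbon would keep any of the gain. Whether the ester oxygens or the shape of the group drive the loss also remains unresolved.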